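The source may hold more compounds than are shown below. What is called first, only, known or untested is meant among the compounds shown, and "the series" means these compounds.

Working notes on the series.

Compound 1 `Cc1nc(-c2ccccc2)c(C(=O)N2CCN(c3cccc(C(N)=O)c3)CC2)o1` is the reference point. Within the data shown here, in a functional assay on HL-60 cells (Homo sapiens) for inhibition, read by MTT assay, with a stated time of 72 h (on this read-out lower numbers stand for stronger inhibition and higher numbers for weaker inhibition), compound 1 gives 71 nM, the lowest of the two numbers measured so far. Among the measured compounds shown here, the only other measured member, compound 2 `COc1cc(OC)cc(N2CCN(C(=O)c3onc(C)c3-c3ccc(-c4ccco4)cc3)CC2)c1`, gives 191 nM in this assay, a higher number that sits beyond the usual scatter; compound 2 differs from compound 1 in several places at once, so it offers no single-point comparison.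

Compound 3 `C=C(C)c1ccc(N2CCN(C(=O)c3oc(C)nc3-c3ccccc3)CC2)cc1` has not yet been measured. It departs from compound 1 by 4-(1-methylethenyl)phenyl in place of 3-carbamoylphenyl on an amine nitrogen in a ring. For the measured compounds named here, no step between measured compounds isolates a change of this kind, so there is no direct precedent in the data; the change swaps a group carrying one hydrogen-bond donor and one hydrogen-bond acceptor for one carrying neither, the rest of the structure being kept.

The expected outcome for compound 3 is a modest rise in the number, roughly at the edge of the scatter, as the step of a 2.0-fold higher number from compound 1 to compound 3 (0.29 log units; within the scatter). Compound 3 is estimated at 140 nM, within a range from 50 nM to 450 nM.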

Compound 3, half-maximal inhibitory concentration: "not active" (no number reported)
Compound 3 has no reported number here; there is nothing to compare the estimate with.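

Among these compounds, compound 3 is reported as not active in this assay without a number, so no step from compound 1 to compound 3 can be read, and no measured evidence bears on this result. The compounds shown leave open how large that difference is and which feature of the change it follows.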